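The source may report more compounds than this note shows. Statements on the series, on what has been measured and on what is new or still open speak of the compounds shown alone.

Measured compounds:
Compound 1, `CC#C[C@@H](Cc1nnn[nH]1)c1ccc(OCc2ccc3scc(C4CCCCC4)c3c2)cc1`, 16 nM
Compound 2, `CC#C[C@@H](Cc1nnn[nH]1)c1ccc(OCc2ccc3scc(-c4ccc(OCCOC)cc4C)c3c2)cc1`, 4 nM

In a functional assay on cells for agonist activity at Free fatty acid receptor 1 (Rattus norvegicus), read by FLIPR and calcium flux (on this read-out higher numbers stand for an effect only at larger amounts of compound and lower numbers for an effect already at smaller amounts), compound 2 stands at the lowest of the two numbers; its nearest neighbour is compound 1, and the step of a 4.0-fold lower number from compound 1 to compound 2 (0.60 log units; beyond the scatter) lies beyond the scatter. That single step is the only one that bears on the change at hand: exchanging cyclohexyl for 4-(2-methoxyethoxy)-2-methylphenyl on the aromatic carbon of the five-membered ring lowered the number modestly.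

Compound 3, `CC#C[C@@H](Cc1nnn[nH]1)c1ccc(OCc2ccc3scc(-c4ccccc4C(F)(F)F)c3c2)cc1`, has not been measured in this assay. It differs from compound 2 by 2-(trifluoromethyl)phenyl in place of 4-(2-methoxyethoxy)-2-methylphenyl on an aromatic carbon. The aromatic ring is kept, but the 2-methoxyethoxy chain and the methyl group are gone and a trifluoromethyl takes their place. Going by the values given here, no measured step tells directly what removing the chain does, so the expectation is framed between compound 1 and compound 2: an aromatic ring without the two hydrogen-bond acceptors is expected to land somewhat above compound 2, most likely a step of a 2.5-fold higher number from compound 2 to compound 3 (0.40 log units; beyond the scatter), within or just beyond the scatter. The estimated value for compound 3 is 10 nM, with a range from 3 nM to 40 nM.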

Compound 3, half-maximal effective concentration: 2 nM
Beside the measured number, compound 3's estimate is 5.0-fold (0.70 log units) above it, outside the stated range (below it).
By their numbers in this assay, from the lowest: compounds 3 and 2 (each within the scatter of the next); then compound 1.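

In this assay, replacing 4-(2-methoxyethoxy)-2-methylphenyl with 2-(trifluoromethyl)phenyl on this aromatic carbon, two ring bonds from the ring sulfur, gives a 2.0-fold lower number from compound 2 to compound 3 (0.30 log units; within the scatter), so the two groups cannot be told apart here, even though the entering group has no hydrogen-bond acceptors and lacks the 2-methoxyethoxy chain. The chain is therefore not required for a low number at this position, which the earlier pair could not show because the chain and the aromatic ring entered together. Against cyclohexyl, the new group gives an 8.0-fold lower number from compound 1 to compound 3 (0.90 log units; beyond the scatter), so among these three compounds both aromatic groups stand clear of cyclohexyl, and none goes against that pattern, but no measurement is available to explain it.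

The two aromatic groups differ in several features at once, so these compounds do not separate the contribution of the trifluoromethyl from that of the methyl, nor show how an unsubstituted phenyl would read. They also leave open how an amine or a carboxylic acid on this aromatic ring would read in this assay.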